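The compounds below may be only part of what the source reports. "The series", "measured", "known", "first", "only" and "open" are said of these compounds alone.

Three compounds share one core and differ only in the group on an aromatic carbon. Compound 1 `C=CC(=O)N1C(=O)CC(c2ccc(C)cc2)Sc2ccccc21` gives 75500 nM in a functional assay on Raji cells (Homo sapiens) for cytotoxicity, read by CCK-8 assay, with a stated time of 24 h; a lower number here means a stronger inhibitor, a higher number a weaker inhibitor. Compound 2 `C=CC(=O)N1C(=O)CC(c2ccc(C(F)(F)F)cc2)Sc2ccccc21` gives 47600 nM, and compound 3 `C=CC(=O)N1C(=O)CC(c2ccc(Cl)cc2)Sc2ccccc21` gives 18400 nM. Compound 2 thus stands second highest of the three, near compound 1 and further from compound 3, with a 1.6-fold lower number from compound 1 to compound 2 (0.20 log units; within the scatter) and a 2.6-fold lower number from compound 2 to compound 3 (0.41 log units; beyond the scatter). Compound 4 `C=CC(=O)N1C(=O)CC(c2ccc(C#N)cc2)Sc2ccccc21` carries cyano in place of trifluoromethyl on an aromatic carbon. Both measured steps bear on this change, since each swaps the same group on the same aromatic carbon, and both were small to modest. The step from compound 2 to compound 4 is therefore expected to be small, at most modest and most likely downward, as a 1.4-fold lower number from compound 2 to compound 4 (0.13 log units; within the scatter). Compound 4 is estimated at 35000 nM, within 12000 nM to 100000 nM.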

Compound 4, half-maximal inhibitory concentration: 84500 nM
Compound 4: middle estimate off by 2.4-fold (0.38 log units), on the low side; measured number inside the range.
By their numbers in this assay, from the lowest: compound 3; then compounds 2, 1 and 4 (each within the scatter of the next).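

In this assay, for the compounds shown here, cyano in place of trifluoromethyl gives a 1.8-fold higher number from compound 2 to compound 4 (0.25 log units; within the scatter), so the downward trend expected from the earlier steps does not appear, and cyano in place of methyl likewise stays within the scatter, with a 1.1-fold higher number from compound 1 to compound 4 (0.05 log units; within the scatter). Chloro alone now stands apart at this position, since cyano in its place gives a 4.6-fold higher number from compound 3 to compound 4 (0.66 log units; beyond the scatter). Nothing given here explains why chloro stands apart. As far as these compounds go, whether bromo, an amine or a carboxylic acid on this aromatic carbon would fall with chloro or with the other three groups remains open.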